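Swapping a methoxy for chloro on an arylpiperazine

The compounds below may be only part of what the source reports. "The series", "measured", "known", "first", "only" and "open" are said of these compounds alone.

Measured so far:
compound 1, `Cc1ccc(-c2cc3[nH]c(=O)n(CCN4CCN(c5ccccc5Cl)CC4)c(=O)c3[nH]2)cc1` — 17.3 nM
compound 2, `COc1ccccc1N1CCN(CCn2c(=O)[nH]c3[nH]c(-c4ccccc4)cc3c2=O)CC1` — 1.99 nM

In an assay on isolated protein for binding affinity to Adrenergic receptor alpha-1 (Homo sapiens) (on this read-out lower numbers stand for stronger inhibition and higher numbers for weaker inhibition), compound 2 gives the lowest of the two numbers; compound 1 sits at a higher number, and the gap between them lies beyond the usual scatter. Compound 3, `O=c1[nH]c2[nH]c(-c3ccccc3)cc2c(=O)n1CCN1CCN(c2ccccc2Cl)CC1`, has not yet been measured. It differs from compound 2 in one place: chloro in place of methoxy on an aromatic carbon. Compound 1 also carries the 2-chlorophenyl, yet it differs from compound 3 in a second place as well, so its value alone cannot fix the step. Without a measured pair for this change, the size of the step is uncertain; the expectation is a moderate weakening, as the step of a 3.0-fold higher number from compound 2 to compound 3 (0.48 log units; beyond the scatter) shows. Compound 3 is therefore expected at about 6 nM, within a range of 2 nM to 20 nM.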

Compound 3, inhibition constant: 4.71 nM
The estimate for compound 3 lay 1.3-fold (0.11 log units) above the measured number, and the stated range covers the measured number.
By their numbers in this assay, from the lowest: compound 2; then compound 3; then compound 1.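

In this assay, replacing the 2-methoxyphenyl with a 2-chlorophenyl on an otherwise unchanged compound gives a 2.4-fold higher number from compound 2 to compound 3 (0.37 log units; beyond the scatter), the first measured size for this change. The step is modest yet beyond the scatter, so the number at this place does respond to the group on the aromatic carbon, while the chloro of compound 3 still leaves a value of 4.71 nM in the low nanomolar range. Nothing available bears on what lies behind this step.

The compounds shown leave open how a fluoro, a hydroxy or a trifluoromethyl on this same aromatic carbon would compare with the methoxy and chloro. They also leave open whether the step keeps its size on the core of compound 1.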